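The compounds below may be only part of what the source reports. "The series", "measured", "known", "first", "only" and "open" are said of these compounds alone.

Measured in a functional assay on Jurkat cells (Homo sapiens) for inhibition, read by CCK-8 assay, with a stated time of 48 h; a higher number here means a weaker inhibitor of growth, a lower number a stronger inhibitor of growth:
- Compound 1 `Cc1ccccc1Nc1nc(NCc2ccncc2)ncc1Cl`: > 100000 nM
- Compound 2 `Cc1ccccc1Nc1nc(Nc2ccc(N3CCN(C(=O)OC(C)(C)C)CC3)cc2)ncc1Cl`: 5120 nM
- Compound 3 `CN1CCN(c2ccc(Nc3ncc(Cl)c(Nc4ccccc4)n3)nc2)CC1`: > 100000 nM

Compound 1 gives > 100000 nM, which is a limit of the assay and not a number. Compound 3 gives > 100000 nM, which is also a limit and not a number. It therefore stands at the limit of > 100000 nM in this assay, at which 2 of the 3 values shown sit. Only compound 2 has a true number, 5120 nM.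

Compound 4 `CN1CCN(c2ccc(Nc3ncc(Cl)c(NCc4ccc(C(F)(F)F)cc4)n3)nc2)CC1` keeps the rest of compound 3 but carries 4-(trifluoromethyl)benzyl in place of phenyl on a nitrogen on an aromatic ring. Going by the values given here, no two measured compounds differ in just one place, so nothing measured shows the size of this change. The value of compound 2, 5120 nM, shows that measurable growth inhibition occurs in this small set. A modest gain in this assay is therefore expected, although another limit would be no surprise. The expected step, an at least 3.3-fold lower number from compound 3 to compound 4 (0.52 log units; beyond the scatter), is toward stronger inhibition and is only roughly estimated. For compound 4, the estimated value is 30000 nM, with an expected range from 6000 nM to 100000 nM.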

Compound 4, concentration for 50% growth inhibition: 7960 nM
Beside the measured number, compound 4's estimate is 3.8-fold (0.58 log units) above it, and the stated range covers the measured number.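

Going by these compounds alone, this is the first pair in the set that differs in one place, and it shows that the group on this nitrogen strongly affects the result: in this assay, 4-(trifluoromethyl)benzyl in place of phenyl gives an at least 12-fold lower number from compound 3 to compound 4 (1.09 log units; beyond the scatter). Compound 3 sits at a limit and not at a number, so the step can only be stated as a minimum size: the limit of > 100000 nM in this assay, at which 2 of the 4 values shown sit. With the rest of compound 3 kept unchanged, this single change is enough to turn a limit into a true measured number.

The compounds shown leave open which part of the new group accounts for the step, the benzyl part or the trifluoromethyl. Plain benzyl, or a longer chain such as 2-phenylethyl, on the same nitrogen would help to separate the two.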